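Swapping phenyl for pyridin-3-yl on a cage amine

A few compounds are considered here, and "the series" means these few. Any claim that something is new, unique, unknown or untested is made for them only; others in the source may bear on it.

Of the compounds shown here, two with a shared cage-like core have been measured. Compound 1 `COc1cc(CN[C@H]2C3C4CC5C6C4CC3C6C52)cc(OC)c1OC` carries a trimethoxybenzyl group on its amine, and in an assay on brain for displacement of a labelled ligand from Sigma non-opioid intracellular receptor 1 (Rattus norvegicus) (a lower number here means a stronger inhibitor, a higher number a weaker inhibitor), compound 1 gives 1010 nM. Compound 2 `CN(Cc1ccccc1)[C@H]1C2C3CC4C2C(=O)C2C4C3C21` carries a methyl and a benzyl group on the amine and a carbonyl in its core, and in this assay compound 2 gives 568 nM. The two numbers lie within the usual scatter of each other, so neither compound can be called the stronger binder.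

Compound 3 `CN(Cc1cccnc1)[C@H]1C2C3CC4C2C(=O)C2C4C3C21` differs from compound 2 in one place: pyridin-3-yl in place of phenyl on a saturated chain carbon bound to an amine nitrogen. Going by the values given here, no measured pair shows the effect of this exact swap, so the expectation rests on the change alone. A small step toward a higher number is expected, a 2.1-fold higher number from compound 2 to compound 3 (0.32 log units; beyond the scatter), though one that may not exceed the scatter. Compound 3 is therefore estimated at 1200 nM, with a likely range from 400 nM to 4000 nM.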

Compound 3, inhibition constant: 734 nM
Compound 3: the middle estimate sits 1.6-fold (0.21 log units) above what was measured; low and high end bracket the measured number.
By their numbers in this assay, from the lowest: compounds 2, 3 and 1 (each within the scatter of the next).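

Going by these compounds alone, the step of a 1.3-fold higher number from compound 2 to compound 3 (0.11 log units; within the scatter) in this assay is the first direct reading of this change: with pyridin-3-yl in place of phenyl on a saturated chain carbon bound to an amine nitrogen, the pair cannot be told apart, even though the entering ring trades a carbon for a nitrogen and brings a hydrogen-bond acceptor. For this pair, then, the position takes either ring without a measurable difference in binding. Nothing measured here speaks to why the swap reads this way.

On these data alone, what stays open is whether the same holds for pyridin-2-yl or pyridin-4-yl, or for a longer chain such as phenylethyl in place of benzyl. A single pair also cannot say whether this swap would read alike on a core without the carbonyl.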